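A few compounds are considered here, and "the series" means these few. Any claim that something is new, unique, unknown or untested is made for them only; others in the source may bear on it.

Of the compounds shown here, three sharing one core have so far been tested in a functional assay on Huh-7 cells (Homo sapiens) for antiproliferative activity, read by CCK-8 assay, with a stated time of 72 h; a higher number here means a weaker inhibitor of growth, a lower number a stronger inhibitor of growth. Compound 1 `CC[C@@H]1C(=O)N(C)c2cnc(Nc3ccc(S(=O)(=O)NC4CCCC4)cc3)nc2N1C1CCCC1` gives 389 nM, the lowest number of the three. Compound 3 `CC[C@@H]1C(=O)N(C)c2cnc(-n3ccc4ccccc43)nc2N1C1CCCC1` gives 4690 nM, and compound 2 `CCC1C(=O)N(C)c2cnc(-n3ccc4cc(C(=O)NCC(C)C)ccc43)nc2N1c1ccn(C)n1` gives 5070 nM. Among the measured compounds shown here, both gaps from compound 1 lie beyond the usual scatter, so compound 1 is the strongest inhibitor of growth among the three measured so far.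

Compound 4 `CC[C@@H]1C(=O)N(C)c2cnc(Nc3ccc(S(=O)(=O)Nc4ccccc4)cc3)nc2N1C1CCCC1` has not yet been measured. It differs from compound 1 in one place: phenyl in place of cyclopentyl on a sulfonamide nitrogen. Cut one bond further out, the same change reads cyclopentylamino to anilino, or cyclopentylsulfamoyl to phenylsulfamoyl. For the measured compounds named here, no measured pair shows this change on its own, and compound 2 and compound 3 differ from compound 1 at several places at once, so nothing measured speaks directly to the sulfonamide end.

The expected step of a 1.4-fold higher number from compound 1 to compound 4 (0.15 log units; within the scatter) is therefore small, with a slight lean toward a higher number, and may well fall within the scatter. Compound 4 is expected to give about 550 nM in this assay, most likely between 150 nM and 2000 nM.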

Compound 4, concentration for 50% growth inhibition: 2790 nM
Compound 4: the middle estimate sits 5.1-fold (0.71 log units) below what was measured; the measured number lies above the stated range.
By their numbers in this assay, from the lowest: compound 1; then compounds 4, 3 and 2 (each within the scatter of the next).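

The sulfonamide end of the molecule turns out to matter: in this assay, phenyl in place of cyclopentyl on a sulfonamide nitrogen gives a 7.2-fold higher number from compound 1 to compound 4 (0.86 log units; beyond the scatter). With the rest of the structure unchanged, this shows that the group on this nitrogen can by itself shift growth inhibition beyond the scatter, and that cyclopentyl serves better here than phenyl. Nothing measured here accounts for the difference.

This swap changes ring size and aromatic character together, so the compounds shown cannot say which of the two matters; cyclohexyl, a six-membered non-aromatic ring, would separate them. Also open, from the compounds shown here alone, is how this position responds to groups other than a carbon ring, such as a short chain like methyl or a chain ending in an amine.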